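Benzyl-group variation on a shared core: working notes

The source may report more compounds than this note shows. Statements on the series, on what has been measured and on what is new or still open speak of the compounds shown alone.

Measured so far:
- compound 1 `CCCn1c(=O)c2nc(-c3cnn(Cc4c(F)cccc4F)c3)[nH]c2n(CCC)c1=O`: "not determined" (no result reported) in an assay on CHO cells for displacement of a labelled ligand from adenosine receptor A1 (Homo sapiens); on this read-out higher numbers stand for weaker inhibition and lower numbers for stronger inhibition
- compound 2 `CCn1c(=O)c2nc(-c3cnn(Cc4ccccc4)c3)[nH]c2n(CC)c1=O`: 580 nM in this assay

Compound 1 stands on no number in this assay; its result is simply absent, so nothing can be said of where it sits relative to compound 2. Compound 2 is the only anchor, and it carries an unsubstituted benzyl and shorter chains on the core, so it is not a direct neighbour of compound 1.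

Compound 3 `CCCn1c(=O)c2nc(-c3cnn(Cc4ccccc4OC)c3)[nH]c2n(CCC)c1=O` is the next candidate. It differs from compound 1 by 2-methoxyphenyl in place of 2,6-difluorophenyl on a saturated chain carbon bound to an aromatic nitrogen. Within the data shown here, with no measured step to lean on, no size can be assigned to this change; the expectation is a step in this assay that stays within the usual scatter, in neither direction with confidence. For compound 3, binding is estimated at 300 nM, expected to fall between 70 nM and 1500 nM, resting only on the value of compound 2.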

Compound 3, inhibition constant: 59 nM
The estimate for compound 3 lay 5.1-fold (0.71 log units) above the measured number; measured number outside the range, below it.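

In this assay no step can be read between compound 1 and compound 3, as compound 1 has no single number to set against compound 3. Going by these compounds, what the change from 2,6-difluorobenzyl to 2-methoxybenzyl does to binding stays open, and no evidence bears on this result.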